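This account rests on a few compounds, and the source may have more. Where it says the series, first, only, none or still open, it means among the compounds named here.

Compound 3 `COC(=O)[C@@H]1CCCN1C(=O)NCc1ccc(C(=O)N2CCCCc3ccccc32)cc1C` gives 100 nM in a functional assay on HEK293 cells for agonist activity at Vasopressin V2 receptor (Homo sapiens), read by a luciferase reporter and cAMP accumulation (a higher number here means that more compound is needed for the effect, a lower number that less compound is needed), the lowest of the three numbers, though compound 1 `Cc1cc(C(=O)N2CCCCc3ccccc32)ccc1CNC(=O)NCC(=O)O` with 180 nM sits within the scatter of it, and compound 2 `Cc1cc(C(=O)N2CCCCc3ccccc32)ccc1CNC(=O)NCC(N)=O` with 210 nM lies just beyond it. Compound 4 `CO[C@@H]1C[C@@H](C(=O)N(C)C)N(C(=O)NCc2ccc(C(=O)N3CCCCc4ccccc43)cc2C)C1` differs from compound 3 by 2-(dimethylcarbamoyl)-4-methoxypyrrolidin-1-yl in place of 2-(methoxycarbonyl)pyrrolidin-1-yl on a carbonyl carbon. For the measured compounds named here, the measured steps of a 1.8-fold lower number from compound 1 to compound 3 (0.26 log units; within the scatter) and a 2.1-fold lower number from compound 2 to compound 3 (0.32 log units; beyond the scatter) change the same carbonyl carbon, yet they exchange the whole group rather than substituents on the pyrrolidin-1-yl ring, so they bear only loosely; all three steps so far stayed small. Going by the values given here, no measured step varies a substituent on that ring. Compound 4 is therefore expected to stay close to compound 3, with no change at the digits printed from compound 3 to compound 4 (within the scatter) not beyond the scatter. The estimate for compound 4 is 100 nM, expected between 35 nM and 300 nM.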

Compound 4, half-maximal effective concentration: 4.7 nM
Estimate against measurement, compound 4: 21-fold (1.33 log units) above; the measured number lies below the stated range.
By their numbers in this assay, from the lowest: compound 4; then compounds 3, 1 and 2 (each within the scatter of the next, the first and the last beyond it).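

The carbonyl carbon, where earlier exchanges of the whole group moved the number little, can carry a large step (a 21-fold lower number from compound 3 to compound 4 (1.33 log units; beyond the scatter)). Compound 4 also stands well clear of the compounds with (carbamoylmethyl)amino (a 45-fold lower number from compound 2 to compound 4 (1.65 log units; beyond the scatter)) and (carboxymethyl)amino (a 38-fold lower number from compound 1 to compound 4 (1.58 log units; beyond the scatter)) on that carbon. No evidence is available to explain this gain.

Going by these compounds, the step to compound 4 combines the dimethylcarbamoyl group with the 4-methoxy group, so its share between the two stays open. A 2-(dimethylcarbamoyl)pyrrolidin-1-yl without methoxy, or a 4-methoxy-2-(methoxycarbonyl)pyrrolidin-1-yl, would separate them.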